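A few compounds are considered here, and "the series" means these few. Any claim that something is new, unique, unknown or untested is made for them only; others in the source may bear on it.

Three compounds have been measured in a functional assay on HL-60 cells (Homo sapiens) for antiproliferative activity, read by MTT assay, with a stated time of 48 h; on this read-out lower numbers stand for stronger inhibition and higher numbers for weaker inhibition:

compound 1, `C[C@H](NC(=O)c1cc2ccccc2cn1)C(=O)OCc1ccccc1`, 84.8 nM
compound 2, `CC(C)[C@H](NC(=O)c1cc2ccccc2cn1)C(=O)OCc1ccccc1`, 78.9 nM
compound 3, `NC(=O)CC[C@H](NC(=O)c1cc2ccccc2cn1)C(=O)OCc1ccccc1`, 44.5 nM

Compound 3 gives the lowest of these three numbers, yet the gaps to its neighbours, a 1.8-fold lower number from compound 2 to compound 3 (0.25 log units; within the scatter) and a 1.9-fold lower number from compound 1 to compound 3 (0.28 log units; within the scatter), both stay within the scatter. Compound 4, `O=C(C[C@H](NC(=O)c1cc2ccccc2cn1)C(=O)OCc1ccccc1)OCc1ccccc1`, arises from compound 3 by benzyloxycarbonyl in place of carbamoylmethyl on a saturated chain carbon, two bonds along the chain from an amide-type nitrogen and a carbonyl carbon. Among the measured compounds shown here, no measured step exchanges one such group for another at that place. The steps that do reach the same chain carbon, a 1.9-fold lower number from compound 1 to compound 3 (0.28 log units; within the scatter) and a 1.8-fold lower number from compound 2 to compound 3 (0.25 log units; within the scatter), were both small, so no step beyond the scatter is expected here either. The estimate for compound 4 is therefore 50 nM, with a range from 20 nM to 130 nM, meaning an expected step of a 1.1-fold higher number from compound 3 to compound 4 (0.05 log units; within the scatter).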

Compound 4, half-maximal inhibitory concentration: 74 nM
Estimate against measurement, compound 4: 1.5-fold (0.17 log units) below; the range from low to high includes it.
By their numbers in this assay, from the lowest: compounds 3, 4, 2 and 1 (each within the scatter of the next).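

In this assay the saturated chain carbon, two bonds along the chain from an amide-type nitrogen and a carbonyl carbon, accepts benzyloxycarbonyl, with its six-membered aromatic ring and no hydrogen-bond donor, in place of carbamoylmethyl, at a 1.7-fold higher number from compound 3 to compound 4 (0.22 log units; within the scatter). The other comparisons, a 1.1-fold lower number from compound 2 to compound 4 (0.03 log units; within the scatter) and a 1.1-fold lower number from compound 1 to compound 4 (0.06 log units; within the scatter), also stay within the scatter, so a much larger ester-bearing group separates from none of the smaller ones. No evidence is available to explain this result.

Going by these compounds, whether a carboxylic acid or an amine at the end of this chain would stay within the scatter remains open.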